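From ethylamino to benzylamino: how fast is removal?

The source may report more compounds than this note shows. Statements on the series, on what has been measured and on what is new or still open speak of the compounds shown alone.

In an ADME assay (liver) for metabolic stability, with Liver microsome (Rattus norvegicus) as the target, using microsomes and NADPH, with a stated time of 30 min, at 37 degrees C, tested at 1 uM (a higher number here means faster removal of the compound, a lower number slower removal), compound 1 `CC(O)(c1ccc(N2CCN(S(=O)(=O)c3ccc(N)nc3)CC2)cc1)C(F)(F)F` gives < 14 mL.min-1.g-1 and this is a limit of the assay, not a number. Compound 2 `CC(O)(c1ccc(-c2ccc(S(=O)(=O)c3ccc(N)nc3)cc2)cc1)C(F)(F)F` gives < 14 mL.min-1.g-1 and this too is a limit. Among the compounds with values here, compound 3 `CCNc1nc(S(=O)(=O)c2ccc(N)nc2)ccc1-c1ccc(C(C)(O)C(F)(F)F)cn1` gives 42 mL.min-1.g-1 as the only true number of the three. Within the data shown here, compound 4 `CC(O)(c1ccc(-c2ccc(S(=O)(=O)c3ccc(N)nc3)nc2NCc2ccccc2)nc1)C(F)(F)F` has benzylamino instead of ethylamino, which means phenyl in place of methyl on a saturated chain carbon bound to a nitrogen on an aromatic ring and no measured pair shows what such a change does. With compound 3 at 42 mL.min-1.g-1 as the starting point, somewhat faster removal is expected. The estimated move is a 1.9-fold higher number from compound 3 to compound 4 (0.28 log units; within the scatter) and it is expected to be modest, near the edge of the usual scatter. For compound 4 the estimated value is 80 mL.min-1.g-1 (expected range 30 mL.min-1.g-1 to 200 mL.min-1.g-1).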

Compound 4, intrinsic clearance in microsomes: 114 mL.min-1.g-1
For compound 4 the middle estimate is 1.4-fold (0.15 log units) below the measured one; measured number inside the range.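

In this assay, phenyl in place of methyl on a saturated chain carbon bound to a nitrogen on an aromatic ring gives a 2.7-fold higher number from compound 3 to compound 4 (0.43 log units; beyond the scatter). Within the data shown here, this is the first readable sign that a change at this place can move intrinsic clearance in microsomes by more than the usual scatter. Compound 1 and compound 2 cannot show this, as each gives a limit of the assay rather than a number: the limit of < 14 mL.min-1.g-1 in this assay, at which 2 of the 4 values shown sit.

One step cannot separate the ring itself from the added carbons. A propyl chain, a cyclohexylmethyl group or a pyridylmethyl group at this place could tell these apart.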